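Removing a Hexyl Chain From a Poorly Soluble Quinolone

The compounds below may be only part of what the source reports. "The series", "measured", "known", "first", "only" and "open" are said of these compounds alone.

Compound 3 `CCCCCCCc1c(C)[nH]c2cc(OC)c(Cl)cc2c1=O` is one of three compounds for which a physicochemical assay for solubility, read by HPLC, at pH 7.4 (on this read-out higher numbers stand for higher solubility and lower numbers for lower solubility), has been recorded. In this assay compound 3 reports only a limit, < 2000 nM, and not a number. Compound 2 `COc1c(Cc2ccccc2)c(C)nc2ccc(Cl)cc12` likewise reports only a limit, < 2000 nM. Compound 1 `CCCCC#Cc1c(C)[nH]c2ccc(F)cc2c1=O` is the only one of the three with a measured number, giving 2000 nM in this assay. Where compound 3 stands can therefore be described only through (the limit of < 2000 nM in this assay, at which 2 of the 3 values shown sit). No pair of these compounds differs in a single place, so no measured step exists among them.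

Compound 4 `COc1cc2[nH]c(C)c(C)c(=O)c2cc1Cl` differs from compound 3 in one place: hydrogen in place of hexyl on a saturated chain carbon bound to an aromatic carbon. Cut one bond further out, the same change reads heptyl to methyl. Nothing measured here shows what this change does to solubility, and the starting point is itself a limit. The expectation is nonetheless that compound 4 rises above that limit, by an at least 4.0-fold higher number from compound 3 to compound 4 (0.60 log units; beyond the scatter) in this assay. The estimate for compound 4 in this assay is 8000 nM, expected to fall within 2000 nM to 40000 nM, with a fair chance that only a limit is reported again.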

Compound 4, solubility: 5000 nM
Beside the measured number, compound 4's estimate is 1.6-fold (0.20 log units) above it; the measured number falls inside the stated range.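

Going by these compounds alone, compound 4 gives the first single change that can be read in this assay: hydrogen in place of hexyl on a saturated chain carbon bound to an aromatic carbon brings an at least 2.5-fold higher number from compound 3 to compound 4 (0.39 log units; beyond the scatter). Compound 3 reports only a limit, < 2000 nM, so this step gives a minimum for the change and not its full size. Unlike compound 3, compound 4 has a measured number, which takes it out of the group of compounds reported only as a limit, and that group remains: the limit of < 2000 nM in this assay, at which 2 of the 4 values shown sit.

This step rests on a single pair of compounds, and the compounds shown leave open whether the same change would read alike on the core of compound 1 or the core of compound 2. They also leave open whether a shorter chain such as propyl in the same place would already give part of this step, and whether an amine or a carboxylic acid there would give a higher number than hydrogen does in compound 4.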